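A few compounds are considered here, and "the series" means these few. Any claim that something is new, unique, unknown or untested is made for them only; others in the source may bear on it.

Measured in a functional assay on the whole organism with Mus musculus as the target; a higher number here means that more compound is needed for the effect, a lower number that less compound is needed:
- Compound 1 `Cc1c(C)c2c(c(C)c1N)CC(C)(CSc1nccn1C)O2`: 37.1 mg/kg
- Compound 2 `Cc1c(C)c2c(c(C)c1N)CC(C)(CSCCO)O2`: > 50 mg/kg (a limit of the assay, not a number)
- Compound 3 `Cc1c(C)c2c(c(C)c1N)CC(C)(CN1CCN(C)CC1)O2`: 25.3 mg/kg

Compound 3 and compound 1 cannot be told apart, as a 1.5-fold lower number from compound 1 to compound 3 (0.17 log units; within the scatter) shows. Compound 2 gives only a limit, so an at least 1.9-fold lower number from compound 2 to compound 3 (0.29 log units; that floor lies within the scatter) is no more than a floor.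

Compound 4 `Cc1c(C)c2c(c(C)c1N)CC(C)(CN1CCN(c3ccccc3)CC1)O2` carries phenyl in place of methyl on an amine nitrogen in a ring. Going by the values given here, no measured pair changes this group alone. Among the compounds with values here, the only steps that bear on it exchange the whole substituent on the saturated chain carbon, and both a 1.5-fold lower number from compound 1 to compound 3 (0.17 log units; within the scatter) and an at least 1.9-fold lower number from compound 2 to compound 3 (0.29 log units; that floor lies within the scatter) stay within the scatter. No step beyond the scatter is therefore expected in this assay, and these data give no firm direction. The estimate is a 1.2-fold higher number from compound 3 to compound 4 (0.07 log units; within the scatter). A result reported only as a limit, as for compound 2, remains possible. For compound 4 the expected value is 30 mg/kg, with an estimated range from 15 mg/kg to 55 mg/kg.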

Compound 4, dose for 50% inhibition: 13.1 mg/kg
The estimate for compound 4 lay 2.3-fold (0.36 log units) above the measured number; measured number outside the range, below it.
By their numbers in this assay, from the lowest: compounds 4, 3 and 1 (each within the scatter of the next, the first and the last beyond it). At a limit, above all of these: compound 2.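

In this assay, phenyl in place of methyl on an amine nitrogen in a ring gives a 1.9-fold lower number from compound 3 to compound 4 (0.29 log units; within the scatter), the first step shown that changes this group alone. This position therefore takes 6 heavy atoms and a six-membered aromatic ring of carbon only in place of 1 heavy atom, and compound 3 and compound 4 still cannot be told apart. Nothing shown here gives a cause for this step.

A single pair leaves open how other groups on this nitrogen would read in the same assay, such as a hydrogen, a benzyl or an acetyl. It also leaves open whether a chlorine or a methoxy on the phenyl would produce a step beyond the scatter.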